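A few compounds are considered here, and "the series" means these few. Any claim that something is new, unique, unknown or untested is made for them only; others in the source may bear on it.

Of the compounds shown here, two sharing one core have been measured so far in a physicochemical assay for solubility, read by nephelometry; on this read-out lower numbers stand for lower solubility and higher numbers for higher solubility. Compound 1 `CC1(C)C(=O)N(c2ccc(SC(F)(F)F)cc2)C(=O)N1Cc1ccnc(NC2CCCCC2)c1` gives < 0.025 ug/mL, which is a limit of the assay and not a number. Compound 2 `CC1(C)C(=O)N(c2ccc(SC(F)(F)F)cc2)C(=O)N1Cc1ccnc(NCc2ccccc2)c1` gives < 0.026 ug/mL, also only a limit, so its standing is known no more closely than that.

The next compound, compound 3 `CCc1cc(CN2C(=O)N(c3ccc(SC(F)(F)F)cc3)C(=O)C2(C)C)ccn1`, carries ethyl in place of benzylamino on an aromatic carbon. Among the compounds with values here, only one measured step bears on this, a step that the two limits leave unreadable from compound 1 to compound 2, which puts benzyl in place of cyclohexyl on a nitrogen on an aromatic ring. Within the data shown here, it gives no size to carry forward, and no measured step removes the whole benzylamino group. The expectation therefore rests on the structural change alone and is loose. Any number that this assay can read for compound 3 is expected to lie upward, though another limit remains quite possible.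

The estimated change is an at least 7.6-fold higher number from compound 2 to compound 3 (0.88 log units; beyond the scatter). For compound 3 the expected value is 0.2 ug/mL. The estimated range for compound 3 runs from 0.02 ug/mL to 5 ug/mL.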

Compound 3, solubility: < 0.022 ug/mL
Compound 3: a limit, no number (the forecaster's own chance of this, stated with the estimate: 40%); at least 9.0-fold (0.95 log units) between middle value and limit.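

In this assay compound 3 gives < 0.022 ug/mL, which is a limit of the assay and not a number. Within the data shown here, compound 1 and compound 2 also stand only at limits, so no step to compound 3 can be read from either. The compounds shown leave open whether ethyl in place of benzylamino on an aromatic carbon changes the solubility read-out at all.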